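A few compounds are considered here, and "the series" means these few. Any claim that something is new, unique, unknown or untested is made for them only; others in the source may bear on it.

Measured in an ADME assay on microsomes from liver (Mus musculus) for metabolic stability, read by LC-MS, using NADPH, with stated times of 10 min and 30 min; on this read-out lower numbers stand for slow clearance and higher numbers for fast clearance:
- compound 1 `O=C1c2ccc(Cl)cc2CN1c1cccnc1`: 76.5 mL/min/kg
- compound 2 `CCC(=O)N[C@@H]1CCCc2c1cncc2N1C(=O)c2ccc(Cl)cc2[C@@H]1C`: < 20.2 mL/min/kg, a limit
- compound 3 `CC(=O)N[C@@H]1CCCc2c1cncc2N1C(=O)c2ccc(Cl)cc2[C@@H]1C`: < 20.2 mL/min/kg, a limit

Compound 3 stands at the limit of < 20.2 mL/min/kg in this assay, at which 2 of the 3 values shown sit. This is a limit and not a number, so the starting point of the next step is not known exactly.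

The next compound, compound 4 `CC(=O)N[C@@H]1CCCc2c1cncc2N1Cc2cc(Cl)ccc2C1=O`, has not been measured. The change is hydrogen in place of methyl on a saturated ring carbon.

Among the measured compounds shown here, the one measured single change is a step that the two limits leave unreadable from compound 2 to compound 3. It also puts hydrogen in place of methyl, but on a chain rather than a ring, and it gives no size to carry over. Compound 1 also has hydrogen on that ring carbon and gives 76.5 mL/min/kg. However, compound 1 differs from compound 4 in other places too, so its value does not size this step.

With so little to go on, only a modest move toward faster clearance is expected, and it may not exceed the usual scatter. The expected step is an at least 1.1-fold higher number from compound 3 to compound 4 (0.07 log units; that floor lies within the scatter). For compound 4 the estimated clearance is 24 mL/min/kg, with an expected range from 12 mL/min/kg to 50 mL/min/kg.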

Compound 4, clearance: < 20.2 mL/min/kg
Compound 4: a limit, no number (the forecaster's own chance of this, stated with the estimate: 50%); middle value at least 1.1-fold (0.07 log units) from the limit.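

Compound 3 and compound 4 each carry only a limit in this assay, not a number, and the step between them cannot be read. The compounds shown leave open how fast compound 4 is actually cleared, and whether hydrogen in place of methyl on the saturated ring carbon changes clearance at all.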